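Replacing hydroxy with (methylamino)methyl on the shared core

A few compounds are considered here, and "the series" means these few. Any claim that something is new, unique, unknown or untested is made for them only; others in the source may bear on it.

Compound 1, `CC(C)(C)c1cc2c(N/N=C/c3ccc(O)cc3)ncnc2s1`: > 10 ug/mL
Compound 2, `CC(C)(C)c1cc2c(N/N=C/c3ccc4c(c3)CNCC4)ncnc2s1`: 0.069 ug/mL

In a functional assay on PC-6 cells (Homo sapiens) for cytotoxicity, read by MTT assay, with a stated time of 3 days (on this read-out higher numbers stand for weaker inhibition and lower numbers for stronger inhibition), compound 1 gives > 10 ug/mL, which is a limit of the assay and not a number. Compound 1 therefore stands at the limit of > 10 ug/mL in this assay, at which 1 of the 2 values shown sits. Compound 2, `CC(C)(C)c1cc2c(N/N=C/c3ccc4c(c3)CNCC4)ncnc2s1`, gives 0.069 ug/mL in this assay. Compound 3, `CNCc1ccc(/C=N/Nc2ncnc3sc(C(C)(C)C)cc23)cc1`, is not yet measured; it differs from compound 1 by (methylamino)methyl in place of hydroxy on an aromatic carbon. Among the measured compounds shown here, since compound 1 gives only a limit, no measured step frames the change. Compound 2 gives 0.069 ug/mL in this assay, and on that basis the step of an at least 66-fold lower number from compound 1 to compound 3 (1.82 log units; beyond the scatter) is expected to be large toward stronger inhibition. Compound 3 is estimated at 0.15 ug/mL, in the range 0.03 ug/mL to 1 ug/mL.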

Compound 3, half-maximal inhibitory concentration: 0.044 ug/mL
Compound 3: middle estimate off by 3.4-fold (0.53 log units), on the high side; measured number inside the range.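

In this assay, (methylamino)methyl in place of hydroxy on an aromatic carbon, para to a large group, brings an at least 220-fold lower number from compound 1 to compound 3 (2.35 log units; beyond the scatter) and so shows that this single change on the shared core is enough for a low number. Compound 1 gives > 10 ug/mL, which is a limit of the assay and not a number. On these data alone, the true size of the step therefore stays unknown, and its reading rests on that limit: the limit of > 10 ug/mL in this assay, at which 1 of the 3 values shown sits.

The compounds shown leave open whether a plain aminomethyl group, a longer chain ending in an amine, or a carboxylic acid at this position would give a similar number.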